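From Compound 1 to Compound 3 in a Cytotoxicity Test

A few compounds are considered here, and "the series" means these few. Any claim that something is new, unique, unknown or untested is made for them only; others in the source may bear on it.

Compound 1 `COc1cc(/C=C2\CCC/C(=C\c3ccc([N+](=O)[O-])cc3)C2=O)ccc1O` was examined in a functional assay on HPC cells (Homo sapiens) for cytotoxicity; on this read-out higher numbers stand for lower toxicity in this test and lower numbers for higher toxicity in this test. In this assay compound 1 gives > 400000 nM, which is a limit of the test rather than a number. Compound 2 `COc1ccc(/C=C2\Cc3ccccc3/C(=C\c3ccc([N+](=O)[O-])cc3)C2=O)cc1` was examined in the same way: in this assay compound 2 gives > 400000 nM, again a limit. Both values shown therefore rest at the limit of > 400000 nM in this assay, at which 2 of the 2 values shown sit, so compound 1 stands at that limit with nothing to set it apart from compound 2. Compound 3 `COc1ccc(/C=C2\CCC/C(=C\c3ccc([N+](=O)[O-])cc3)C2=O)cc1` has not yet been measured. It differs from compound 1 by 4-methoxyphenyl in place of 4-hydroxy-3-methoxyphenyl on a double-bonded chain carbon bound to a double-bonded ring carbon. For the measured compounds named here, no measured step between two compounds is available, so the size of this change cannot be read from a measurement. Compound 3 is expected to stay at the limit, an expected step of a number no higher from compound 1 to compound 3 (the limit leaves the size open), none beyond the scatter. The estimate for compound 3 is 400000 nM, with a range from 150000 nM to 1000000 nM.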

Compound 3, half-maximal cytotoxic concentration: > 400000 nM
Compound 3 gave a limit, no number; the forecaster's own chance of this, stated with the estimate: 85%; the middle value sits exactly at the limit.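

Compound 3 gives > 400000 nM in this assay, a limit and not a number, so no step can be read from compound 1 to compound 3. The compounds shown leave open whether 4-methoxyphenyl in place of 4-hydroxy-3-methoxyphenyl changes the read-out at all, since none gives a number: the limit of > 400000 nM in this assay, at which 3 of the 3 values shown sit.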